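Diaryl ether to diarylamine: the step to compound 4

The source may report more compounds than this note shows. Statements on the series, on what has been measured and on what is new or still open speak of the compounds shown alone.

Three measured compounds share a core and differ only in the aryl group on the oxygen. Compound 1 `Cc1ccccc1Oc1ccc(C#N)cc1S(=O)(=O)NC(=O)NC(C)(C)C` gives 966 nM in a functional assay on cells (Platelet, Homo sapiens) for inhibition, with a stated time of 1 min, tested at 1 uM; a higher number here means a weaker inhibitor, a lower number a stronger inhibitor. Compound 2 `Cc1cccc(Oc2ccc(C#N)cc2S(=O)(=O)NC(=O)NC(C)(C)C)c1` gives 705 nM in this assay, and compound 3 `Cc1ccc(Oc2ccc(C#N)cc2S(=O)(=O)NC(=O)NC(C)(C)C)cc1` gives 649 nM. Compound 3 has the lowest of the three numbers, but its neighbours sit close: a 1.5-fold lower number from compound 1 to compound 3 (0.17 log units; within the scatter), a 1.1-fold lower number from compound 2 to compound 3 (0.04 log units; within the scatter), and a 1.4-fold lower number from compound 1 to compound 2 (0.14 log units; within the scatter). None of these steps leaves the scatter, so moving the methyl around the phenyl ring shows no effect that can be trusted.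

Compound 4 `Cc1ccccc1Nc1ccc(C#N)cc1S(=O)(=O)NC(=O)NC(C)(C)C` has not been measured. Relative to compound 3 the change is (2-methylphenyl)amino in place of 4-methylphenoxy on an aromatic carbon. Two things move at once: the methyl returns to the position it has in compound 1, and the oxygen linker becomes an amino linker. The methyl move is covered by the measured steps and was within the scatter. Among the measured compounds shown here, for the oxygen-to-nitrogen exchange no measured pair gives a precedent, so the direction of any step in this assay is open. The expected step of a 1.4-fold higher number from compound 3 to compound 4 (0.14 log units; within the scatter) is therefore estimated as small, with a wide band. Compound 4 is expected to give about 900 nM in this assay, between 300 nM and 3000 nM.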

Compound 4, half-maximal inhibitory concentration: 971 nM
Compound 4: the middle estimate sits 1.1-fold (0.03 log units) below what was measured; the measured number falls inside the stated range.
By their numbers in this assay, from the lowest: compounds 3, 2, 1 and 4 (each within the scatter of the next).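

Among the compounds shown here, compound 1 and compound 4 are the first pair that isolates the linker: with the 2-methylphenyl group held fixed, the exchange of oxygen for amino gives a 1.0-fold higher number from compound 1 to compound 4 (0.00 log units; within the scatter) in this assay, and the hydrogen-bond donor that enters with the amino group leaves no readable change at this aromatic carbon. The other two new steps, a 1.5-fold higher number from compound 3 to compound 4 (0.17 log units; within the scatter) and a 1.4-fold higher number from compound 2 to compound 4 (0.14 log units; within the scatter), also stay within the scatter, although each moves the methyl as well as exchanging the linker. At this position, the four compounds therefore do not separate in this assay, whether the linker is oxygen or amino. No evidence is available that bears on this result.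

For the compounds shown here, it remains open whether the amino linker behaves the same way with the methyl on the 3- or 4-position of the phenyl ring, as the only amino compound here carries the 2-methylphenyl group. Also open, on these data alone, is how this assay responds to a methylene or carbonyl linker, or to a carboxylic acid or dimethylamino group on the phenyl ring in place of the methyl.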